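N-Methylation of the amine in compound 1

A few compounds are considered here, and "the series" means these few. Any claim that something is new, unique, unknown or untested is made for them only; others in the source may bear on it.

Compound 1 `CCCCNCCCOc1cccc(O)c1C(=O)CC` gives 18.3% in an assay on isolated protein for inhibition of glucose-6-phosphatase catalytic subunit 1 (Homo sapiens), tested at 100 uM; a lower number here means less inhibition, a higher number more inhibition at the concentration tested (going by the name of the read-out). Going by the values given here, its only measured neighbour is compound 2 `CCC(=O)c1c(O)cccc1OCCCNc1ccc(C)cc1`, which gives 18.9% in this assay; the two numbers stand together within the usual scatter, the change being a number 0.6 percentage points higher from compound 1 to compound 2 (within the scatter). Among the compounds with values here, compound 1 thus stands level with the single other number.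

Compound 3 `CCCCN(C)CCCOc1cccc(O)c1C(=O)CC` is not yet measured. It differs from compound 1 by methyl in place of hydrogen on an amine nitrogen. Within the data shown here, the one measured step, from compound 1 to compound 2, touches the same amine nitrogen, where a 4-methylphenyl replaced the butyl, and it stayed within the scatter. Among the measured compounds shown here, no measured step puts a methyl onto that nitrogen, so the bearing of the present change is inferred only from the flat neighbour step. The expectation for this assay is therefore a step of a number 0.7 percentage points higher from compound 1 to compound 3 (within the scatter), none beyond the scatter. Compound 3 is estimated at 19%, in the range 6% to 34%.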

Compound 3, a percentage reported as inhibition, at one concentration (the size of the read-out at that concentration, not a potency): 17.3%
Estimate against measurement, compound 3: 1.7 percentage points above; the measured number falls inside the stated range.
By their numbers in this assay, from the lowest: compounds 3, 1 and 2 (each within the scatter of the next).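

In this assay, methyl in place of hydrogen on the amine nitrogen gives a number 1 percentage points lower from compound 1 to compound 3 (within the scatter) and so the loss of that hydrogen leaves the read-out within the scatter. The earlier step of a number 0.6 percentage points higher from compound 1 to compound 2 (within the scatter) changed the butyl on the same nitrogen, so both substituent changes now read flat, one on the hydrogen and one on the butyl. Nothing available explains this flat result.

On these data alone, whether a larger group on this nitrogen, such as an acetyl that turns the amine into an amide, would move the number beyond the scatter stays open. So does the effect of a carboxylic acid on the end of the butyl chain, or of removing the amine from the core of compound 1 altogether.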